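A few compounds are considered here, and "the series" means these few. Any claim that something is new, unique, unknown or untested is made for them only; others in the source may bear on it.

In an ADME assay on L02 cells (Homo sapiens) for cytotoxicity, read by MTT assay, with a stated time of 48 h (a lower number here means a stronger inhibitor, a higher number a weaker inhibitor), three amides built on one shared core have been measured. Compound 1 (`CCN(CC)CCNC(=O)c1ccc(C(CC)(CC)c2ccc(OCC(O)C(C)(C)C)c(C)c2)n1CC`) gives 2500 nM, and compound 2 (`CCn1c(C(=O)NCCN(C)C)ccc1C(CC)(CC)c1ccc(OCC(O)C(C)(C)C)c(C)c1`) gives 2600 nM. Compound 3 (`CCn1c(C(=O)N(C)CCC#N)ccc1C(CC)(CC)c1ccc(OCC(O)C(C)(C)C)c(C)c1`) gives 14900 nM, the highest number of the three.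

Compound 4 (`CC[C@@H](C)[C@H](NC(=O)c1ccc(C(CC)(CC)c2ccc(OCC(O)C(C)(C)C)c(C)c2)n1CC)C(=O)O`) departs from compound 3 through ((1-carboxy-2-methylbutyl)amino in place of (2-cyanoethyl)(methyl)amino on a carbonyl carbon). In words, (1-carboxy-2-methylbutyl)amino stands in place of (2-cyanoethyl)(methyl)amino on a carbonyl carbon.

Two measured steps changed this same place: a 6.0-fold higher number from compound 1 to compound 3 (0.78 log units; beyond the scatter), and a 5.7-fold higher number from compound 2 to compound 3 (0.76 log units; beyond the scatter). Both were modest and upward. A third, a 1.0-fold higher number from compound 1 to compound 2 (0.02 log units; within the scatter), exchanged only the amine end of the chain. Within the data shown here, no measured compound carries a carboxy group, so these steps bear on the change only indirectly.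

Compound 4, like compound 3 at 14900 nM, lacks the diethylamino and dimethylamino groups, so the rise seen on losing them is expected to be already contained in the starting value. Only a small further rise is therefore expected, with real uncertainty in both directions. The expected step is a 1.7-fold higher number from compound 3 to compound 4 (0.22 log units; within the scatter). For compound 4 the estimated value is 25000 nM, with an expected range of 8000 nM to 70000 nM.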

Compound 4, half-maximal inhibitory concentration: 1400 nM
Beside the measured number, compound 4's estimate is 18-fold (1.25 log units) above it; measured number outside the range, below it.
By their numbers in this assay, from the lowest: compounds 4, 1 and 2 (each within the scatter of the next); then compound 3.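

In this assay the change on this carbonyl carbon gives an 11-fold lower number from compound 3 to compound 4 (1.03 log units; beyond the scatter), which shows that losing the diethylamino or dimethylamino end does not by itself bring a high number: (1-carboxy-2-methylbutyl)amino carries neither group, yet compound 4 sits level with the amine-bearing amides. The steps of a 1.9-fold lower number from compound 2 to compound 4 (0.27 log units; within the scatter) and a 1.8-fold lower number from compound 1 to compound 4 (0.25 log units; within the scatter) both lie within the scatter, so among these four amides compound 3 alone stands apart, and a terminal amine is not required for a number in this range. No evidence is available to explain this result.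

The compounds shown leave open whether the high number of compound 3 goes with its nitrile or with the methyl on the amide nitrogen: (2-cyanoethyl)(methyl)amino brings both, while the other three amides keep the amide hydrogen. They also leave open whether the carboxylic acid or the branched sec-butyl chain of compound 4 matters here, a question that a methyl ester or a simple butylamine amide at this carbonyl carbon could separate.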